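Notes on replacing chloro in compound 1

The compounds below may be only part of what the source reports. "The series", "measured", "known", "first", "only" and "open" are said of these compounds alone.

- compound 1 `CNc1nccc(N2CC[C@H](NC(=O)Nc3ccc(Cl)c(C(F)(F)F)c3)C2)n1`: 3.9 10^-6 cm/s
- compound 2 `CNc1nccc(N2CC[C@H](NC(=O)Nc3ccc(C)c(Cl)c3)C2)n1`: 3.9 10^-6 cm/s

In an ADME assay on MDCK cells (Canis lupus familiaris) for permeability, in the apical to basolateral direction (on this read-out lower numbers stand for lower permeability and higher numbers for higher permeability), compound 1 gives 3.9 10^-6 cm/s and stands level with compound 2, within the scatter. Compound 3 `CCN1CCN(Cc2ccc(NC(=O)N[C@H]3CCN(c4ccnc(NC)n4)C3)cc2C(F)(F)F)CC1` has not yet been measured. It carries (4-ethylpiperazin-1-yl)methyl in place of chloro on an aromatic carbon, ortho to a trifluoromethyl group ((4-ethylpiperazin-1-yl)methyl in place of chloro on an aromatic carbon). For the measured compounds named here, no measured step covers a change of this kind, so the expectation rests on judgement alone. The expected move is downward and beyond the scatter, with a 2.6-fold lower number from compound 1 to compound 3 (0.41 log units; beyond the scatter) as the estimated step in this assay for this change. Compound 3 is estimated at 1.5 10^-6 cm/s with an expected range from 0.5 10^-6 cm/s to 4 10^-6 cm/s for now.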

Compound 3, apparent permeability: 0.3 10^-6 cm/s
For compound 3 the middle estimate is 5.0-fold (0.70 log units) above the measured one; measured number outside the range, below it.
By their numbers in this assay, from the lowest: compound 3; then compounds 1 and 2 (each within the scatter of the next).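

Replacing chloro with (4-ethylpiperazin-1-yl)methyl on this aromatic carbon, ortho to a trifluoromethyl group, gives a 13-fold lower number from compound 1 to compound 3 (1.11 log units; beyond the scatter) in this assay. This position therefore does not tolerate every group without change in this read-out, which compounds 1 and 2 alone could not show. Nothing measured here accounts for the size of this step.

Open, on these data alone, is whether the ring, its ethyl group or the added nitrogens carry the step. A morpholin-4-ylmethyl or dimethylaminomethyl group at this position would help separate these parts.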